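A few compounds are considered here, and "the series" means these few. Any claim that something is new, unique, unknown or untested is made for them only; others in the source may bear on it.

Three compounds of this series have so far been run through an ADME assay on Caco-2 cells (Homo sapiens) for permeability, in the apical to basolateral direction; a lower number here means that the compound crosses the layer more slowly, a higher number that the compound crosses the layer faster. Compound 1 `CNC(=O)c1cc(Oc2ccc3sc(Nc4cccc(C(C)(C)C)c4)nc3c2)ccn1` gives 10 10^-6 cm/s in this assay. Compound 2 `CNC(=O)c1cc(Oc2ccc3oc(Nc4ccccc4F)nc3c2)ccn1` gives 10 10^-6 cm/s in this assay, and compound 3 `CNC(=O)c1cc(Oc2ccc3oc(Nc4ccccc4Cl)nc3c2)ccn1` gives 10 10^-6 cm/s in this assay. Among the compounds with values here, the only one-place step among the measured compounds, no change at the digits printed from compound 2 to compound 3 (within the scatter), leaves the read-out where it was. Compound 3 therefore stands level with compounds 1 and 2 on the numbers shown; its nearest neighbour is compound 1 and its furthest is compound 2, and neither gap goes beyond the scatter.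

Compound 4 `CNC(=O)c1cc(Oc2ccc3oc(Nc4cccc(C(F)(F)F)c4)nc3c2)ccn1` has not yet been measured in this assay. The change from compound 3 to compound 4 is 3-(trifluoromethyl)phenyl in place of 2-chlorophenyl on a nitrogen on an aromatic ring. Within the data shown here, the one measured step that bears on it, no change at the digits printed from compound 2 to compound 3 (within the scatter), also exchanged one aryl group for another on that same nitrogen and gave no change beyond the scatter; compounds 1 and 2 differ from each other there as well and read the same in this assay. Nothing in the measured set suggests that the group on this nitrogen moves the read-out. The step of no change at the digits printed from compound 3 to compound 4 (within the scatter) is accordingly expected to stay within the scatter, with no direction to it. Compound 4 is expected to give 10 10^-6 cm/s in this assay, within a range from 5 10^-6 cm/s to 20 10^-6 cm/s.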

Compound 4, apparent permeability: 10 10^-6 cm/s
Compound 4: middle estimate and measured number agree at the digits printed, and the stated range covers the measured number.
By their numbers in this assay, from the lowest: compounds 1, 2, 3 and 4 (each within the scatter of the next).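

Notes on the group on the nitrogen: the read-out in this assay now holds through more than the chloro-for-fluoro exchange, with no change at the digits printed from compound 3 to compound 4 (within the scatter) on replacing 2-chlorophenyl by 3-(trifluoromethyl)phenyl and no change at the digits printed from compound 2 to compound 4 (within the scatter) on replacing 2-fluorophenyl by the same group. The group entering at this place has 10 heavy atoms against 7 for 2-chlorophenyl, and its substituent is a trifluoromethyl rather than a single halogen, so the tolerated range at this nitrogen is wider than the earlier step showed. Among compounds 2, 3 and 4, which differ only in this aryl group, no compound goes against that flat picture, and nothing at hand explains it.

As far as these compounds go, all three of these groups are phenyl rings with no hydrogen-bond donors or acceptors and no net charge, so the effect in this assay of an amine or a carboxylic acid on that ring remains open. Also open, from the compounds shown here alone, is whether a longer alkyl chain in place of the aryl group on this nitrogen, or a change to the methyl amide of the shared core, would move the read-out.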